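A nitro group added to a thromboxane receptor sulfonamide

The source may report more compounds than this note shows. Statements on the series, on what has been measured and on what is new or still open speak of the compounds shown alone.

Measured compounds:
- compound 1, `O=C(O)CCCCCC[C@@H]1[C@@H](CNS(=O)(=O)c2ccc(F)cc2)CC[C@H]1F`: 6000 nM
- compound 2, `O=C(O)CCC/C=C\C[C@H]1[C@H](F)CC[C@@H]1NS(=O)(=O)c1ccccc1`: 1100 nM
- compound 3, `O=C(O)COCCCCC1=CCC[C@@H]1NS(=O)(=O)c1ccccc1[N+](=O)[O-]`: 1900 nM

Of the compounds shown here, three have been tested in a functional assay on a cell-free system (plasma) for inhibition of thromboxane A2 receptor (Homo sapiens), read by turbidimetry; on this read-out higher numbers stand for weaker inhibition and lower numbers for stronger inhibition. Compound 1 gives 6000 nM, compound 2 gives 1100 nM, and compound 3 gives 1900 nM. Compound 2 has the lowest of the three numbers. Its gap to compound 3 lies within the usual scatter of repeated measurements, so the two cannot be ranked against each other; its gap to compound 1 lies beyond the scatter, so compound 2 is the stronger inhibitor of that pair.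

The next compound to be measured is compound 4, `O=C(O)CCC/C=C\C[C@H]1[C@H](F)CC[C@@H]1NS(=O)(=O)c1ccccc1[N+](=O)[O-]`. It differs from compound 2 in one place: nitro in place of hydrogen on an aromatic carbon. Compound 3 already carries a 2-nitrophenyl sulfonamide, but it also differs from compound 2 in its core and chain, so its value says nothing on its own about this single change. Among the measured compounds shown here, no step between measured compounds shows what the nitro group alone does.

With that in mind, the step from compound 2 to compound 4 is expected to be small, no change at the digits printed from compound 2 to compound 4 (within the scatter), in either direction and not beyond the scatter. Compound 4 is therefore estimated at 1100 nM, in a range from 350 nM to 3500 nM.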

Compound 4, half-maximal inhibitory concentration: 1800 nM
For compound 4 the middle estimate is 1.6-fold (0.21 log units) below the measured one; measured number inside the range.
By their numbers in this assay, from the lowest: compounds 2, 4 and 3 (each within the scatter of the next); then compound 1.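

In this assay, among the compounds shown here, nitro in place of hydrogen on an aromatic carbon gives a 1.6-fold higher number from compound 2 to compound 4 (0.21 log units; within the scatter), and this is the first reading of that single change. It shows that this carbon of the benzenesulfonamide, ortho to a large group, accepts a nitro group on the core and chain of compound 2 with no shift that can be told from the scatter of repeated measurements. Compound 3 carries the same 2-nitrophenyl group but could not show this, as its core and chain differ as well. The data shown offer no measurement that would explain this result.

Still open, going by these compounds, is whether a smaller or differently built group at this same carbon, such as an amine, a methoxy group or a chlorine atom, would leave the number just as unmoved, or whether a nitro group placed elsewhere on the ring would do so. It is also open whether phenyl to 2-nitrophenyl gives a similar step on the core and chain of compound 3, whose phenyl counterpart is not among the compounds shown.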